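The compounds below may be only part of what the source reports. "The series", "measured", "known", "first", "only" and "open" are said of these compounds alone.

Measured so far:
- compound 1 `CCCOc1cc(=O)oc2cc(OCc3ccccc3)ccc12`: 575 nM
- compound 2 `COc1cc(=O)oc2cc(OCc3cccc(F)c3)ccc12`: 36.3 nM

In an assay on isolated protein (strain Sprague-Dawley) for inhibition of Amine oxidase [flavin-containing] B (Rattus norvegicus), read by spectrophotometry, with a stated time of 5 min (on this read-out lower numbers stand for stronger inhibition and higher numbers for weaker inhibition), compound 2 gives the lowest number of the two, and compound 1 sits a clear distance above it, well beyond the scatter. Among the measured compounds shown here, the two differ in two places at once, so no single step between them can be read out; what the pair shows is only that the combination of methoxy with the fluorinated benzyloxy group is matched with the lower number.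

Compound 3 `CCCOc1cc(=O)oc2cc(OCc3cccc(F)c3)ccc12` is not yet measured. Against compound 2 the change is ethyl in place of hydrogen on a saturated chain carbon bound to an oxygen on an aromatic ring, that is, methoxy to propoxy, with the fluorinated benzyloxy group kept. For the measured compounds named here, no measured pair isolates this change. Going by the values given here, the only hint is compound 1, which carries the propoxy group and gives 575 nM, but its second difference from compound 2 leaves the share of the alkoxy change open.

The working expectation for compound 3 is a moderate rise in the number in this assay, estimated as a 4.1-fold higher number from compound 2 to compound 3 (0.62 log units; beyond the scatter), with the outcome possibly still within the scatter. Compound 3 is estimated at 150 nM, with a likely range from 40 nM to 600 nM.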

Compound 3, half-maximal inhibitory concentration: 407 nM
Estimate against measurement, compound 3: 2.7-fold (0.43 log units) below; the measured number falls inside the stated range.
By their numbers in this assay, from the lowest: compound 2; then compounds 3 and 1 (each within the scatter of the next).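

In this assay the step methoxy to propoxy, with the fluorinated benzyloxy group kept, can now be read on its own and is large, with an 11-fold higher number from compound 2 to compound 3 (1.05 log units; beyond the scatter) for this one change on a saturated chain carbon bound to an oxygen on an aromatic ring. Fluoro in place of hydrogen on an aromatic carbon, read with the propoxy group kept, gives a 1.4-fold lower number from compound 1 to compound 3 (0.15 log units; within the scatter) and so shows no change beyond the scatter in this setting. Among the compounds shown here, of the two single changes now readable, the alkoxy step is the one that moves the number, a contrast that rests on only one pair for each change.

On these data alone, whether the fluoro step stays this small with methoxy in place remains open, as does how the number runs through ethoxy, a longer chain such as butoxy, or a chain ending in an amine. Nothing at hand gives a reason for the size of the alkoxy step.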